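The source may hold more compounds than are shown below. What is called first, only, known or untested is meant among the compounds shown, and "the series" means these compounds.

Of the compounds shown here, three sharing one core have been measured in an ADME assay on microsomes from liver (Mus musculus) for metabolic stability; a lower number here means slower removal, a higher number faster removal of the compound. Compound 1 `CCn1nc(CC(=O)Nc2ccc(OC(F)(F)F)c(Cl)c2)c2ccccc2c1=O`, with ethyl on the aromatic nitrogen, gives 81.7 mL/min/kg. Compound 2 `O=C(Cc1nn(CC(=O)N2CCOCC2)c(=O)c2ccccc12)Nc1ccc(OC(F)(F)F)c(Cl)c1` gives 11900 mL/min/kg, and compound 3 `O=C(Cc1nn(C2CCNC2)c(=O)c2ccccc12)Nc1ccc(OC(F)(F)F)c(Cl)c1` gives 16300 mL/min/kg. Compound 3 therefore sits with compound 2 at the high end of the range, as the step of a 1.4-fold higher number from compound 2 to compound 3 (0.14 log units; within the scatter) shows.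

Compound 4 `O=C(Cc1nn(C2CC2)c(=O)c2ccccc12)Nc1ccc(OC(F)(F)F)c(Cl)c1` carries cyclopropyl in place of pyrrolidin-3-yl on an aromatic nitrogen. The closest guide is a 200-fold higher number from compound 1 to compound 3 (2.30 log units; beyond the scatter), where pyrrolidin-3-yl replaces ethyl. The step of a 150-fold higher number from compound 1 to compound 2 (2.16 log units; beyond the scatter), with (morpholin-4-yl)carbonyl in place of methyl, is of similar size. Cyclopropyl, like ethyl, contains carbon only, so a large move down towards compound 1 at 81.7 mL/min/kg is expected. Within the data shown here, no measured compound carries cyclopropyl, however, so the range stays wide.

The expected change is an 82-fold lower number from compound 3 to compound 4 (1.91 log units; beyond the scatter). For compound 4 the estimated clearance is 200 mL/min/kg, with an expected range from 50 mL/min/kg to 3000 mL/min/kg.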

Compound 4, clearance: 2300 mL/min/kg
Beside the measured number, compound 4's estimate is 12-fold (1.06 log units) below it; low and high end bracket the measured number.
By their numbers in this assay, from the lowest: compound 1; then compound 4; then compounds 2 and 3 (each within the scatter of the next).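

Cyclopropyl and ethyl both contain carbon only, yet exchanging ethyl for cyclopropyl on the aromatic nitrogen still raises the number in this assay by a large step (a 28-fold higher number from compound 1 to compound 4 (1.45 log units; beyond the scatter)). An all-carbon group at this position is therefore no guarantee of a number close to that of compound 1. Cyclopropyl also lies clearly under the two larger nitrogen-bearing groups (a 7.1-fold lower number from compound 3 to compound 4 (0.85 log units; beyond the scatter); a 5.2-fold lower number from compound 2 to compound 4 (0.71 log units; beyond the scatter)), which places compound 4 in the middle of the series rather than at either end.

Nothing shown here explains why two small carbon groups at this position differ so much. From the compounds shown here alone, it remains open whether a longer chain such as propyl, a cyclobutyl ring or an open-chain amine on this nitrogen would sit nearer compound 1 or nearer compound 3.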